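A dichlorobenzyl isomer of compound 3 awaits its number

A few compounds are considered here, and "the series" means these few. Any claim that something is new, unique, unknown or untested is made for them only; others in the source may bear on it.

In a functional assay on DU-145 cells (Homo sapiens) for inhibition, read by trypan blue exclusion, with a stated time of 96 h (on this read-out higher numbers stand for weaker inhibition of growth and lower numbers for stronger inhibition of growth), compound 1 (`COc1cc(OC)c(/C=C(/Sc2ccc(C)cc2)C(=O)c2ccc(Cl)cc2)c(OC)c1`) reads > 100000 nM, and this value is a limit of the assay. Compound 2 (`Cc1ccc(S/C(=C/c2ccc(C)s2)C(=O)c2ccc(Br)cc2)cc1`) reads > 100000 nM, which is also a limit. Going by the values given here, compound 3 (`COc1cc(OC)c(/C=C(/SCc2ccc(Cl)c(Cl)c2)C(=O)c2ccc(Cl)cc2)c(OC)c1`) gives 10000 nM, the only actual number so far. The rest of the picture is the limit of > 100000 nM in this assay, at which 2 of the 3 values shown sit.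

Compound 4 (`COc1cc(OC)c(/C=C(/SCc2ccc(Cl)cc2Cl)C(=O)c2ccc(Cl)cc2)c(OC)c1`) keeps the atoms of compound 3 but joins them differently: 2,4-dichlorophenyl in place of 3,4-dichlorophenyl on a saturated chain carbon bound to a sulfur. In words, 2,4-dichlorophenyl stands in place of 3,4-dichlorophenyl on a saturated chain carbon bound to a sulfur.

Among the compounds with values here, only one measured step bears on this change, and only loosely. It is an at least 10-fold lower number from compound 1 to compound 3 (1.00 log units; beyond the scatter), with 3,4-dichlorobenzyl in place of 4-methylphenyl on a sulfur. That step shows that the group on the sulfur can shift the number beyond the scatter, but it replaced a whole group, so it does not size a change within the dichlorobenzyl group. Within the data shown here, no measured pair tests that change directly.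

The expectation therefore starts from compound 3 at 10000 nM, with no clear direction. The expected change in this assay is no change at the digits printed from compound 3 to compound 4 (within the scatter), which would stay within the scatter. For compound 4 the estimated value is 10000 nM, with an expected range of 2500 nM to 40000 nM.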

Compound 4, concentration for 50% growth inhibition: 1000 nM
Beside the measured number, compound 4's estimate is 10-fold (1.00 log units) above it; the measured number lies below the stated range.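

In this assay, the arrangement of the two chlorines on the ring matters in its own right: with the atoms unchanged, 2,4-dichlorophenyl in place of 3,4-dichlorophenyl on a saturated chain carbon bound to a sulfur gives a 10-fold lower number from compound 3 to compound 4 (1.00 log units; beyond the scatter). Going by these compounds alone, the earlier step showed only that replacing a whole group on the sulfur could shift the number, whereas this one shows that rearranging the atoms within that group is enough to do so, and the 2,4-dichlorobenzyl group gives an at least 100-fold lower number from compound 1 to compound 4 (2.00 log units; beyond the scatter). Compound 1 sits at a limit and not at a number, so this second step gives only a bound on the size of the change: the limit of > 100000 nM in this assay, at which 2 of the 4 values shown sit.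

The compounds shown leave open whether both chlorines are needed for this result, and whether a 2-chlorobenzyl or 4-chlorobenzyl group on the sulfur would read like compound 4 or like compound 3. They also leave open whether a longer chain, such as 2-(2,4-dichlorophenyl)ethyl, would hold the number of compound 4, and they do not tell why the two isomers differ.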